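Adding a third methoxy to the benzyl of compound 3

The source may report more compounds than this note shows. Statements on the series, on what has been measured and on what is new or still open speak of the compounds shown alone.

Compound 3, `COc1ccc(Cn2cc(CN(Cc3cn(S(=O)(=O)c4ccc(C)cc4)c4ccccc34)S(=O)(=O)c3ccc(C)cc3)nn2)c(OC)c1`, is one of three sulfonamides that differ only in the aryl group on the saturated chain carbon bound to the aromatic nitrogen. In a functional assay on 3T3-L1 cells (Mus musculus) for inhibition, with a stated time of 20 min, tested at 20 uM (a higher number here means more inhibition at the concentration tested (going by the name of the read-out), a lower number less inhibition), compound 3 gives 7.6%, the second highest of the three numbers. Compound 2, `Cc1ccc(S(=O)(=O)N(Cc2cn(Cc3ccc(F)cc3F)nn2)Cc2cn(S(=O)(=O)c3ccc(C)cc3)c3ccccc23)cc1`, gives 12.3% in this assay, and the difference a number 4.7 percentage points lower from compound 2 to compound 3 (within the scatter) lies within the scatter. Compound 1, `COc1cc(OC)c(Cn2cc(CN(Cc3cn(S(=O)(=O)c4ccc(C)cc4)c4ccccc34)S(=O)(=O)c3ccc(C)cc3)nn2)c(OC)c1`, gives -22%, and the step of a number 29.6 percentage points higher from compound 1 to compound 3 (beyond the scatter) is beyond the scatter, as is a number 34.3 percentage points higher from compound 1 to compound 2 (beyond the scatter).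

Compound 4, `COc1ccc(Cn2cc(CN(Cc3cn(S(=O)(=O)c4ccc(C)cc4)c4ccccc34)S(=O)(=O)c3ccc(C)cc3)nn2)c(OC)c1OC`, is not yet measured. It differs from compound 3 by methoxy in place of hydrogen on an aromatic carbon.

Among the measured compounds shown here, only one measured step bears on this change: the step from compound 1 to compound 3, in which a methoxy left and inhibition rose by a number 29.6 percentage points higher from compound 1 to compound 3 (beyond the scatter). The new step runs the other way, a methoxy entering, though at a different place on the ring, so the size is uncertain. The account therefore expects a small downward step, a number 10.6 percentage points lower from compound 3 to compound 4 (beyond the scatter), that may well sit within the scatter. The estimate for compound 4 in this assay is -3%, with a range from -28% to 18%.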

Compound 4, a percentage reported as inhibition, at one concentration (the size of the read-out at that concentration, not a potency): -18%
For compound 4 the middle estimate is 15 percentage points above the measured one; measured number inside the range.
By their numbers in this assay, from the lowest: compounds 1 and 4 (each within the scatter of the next); then compounds 3 and 2 (each within the scatter of the next).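

In this assay, methoxy in place of hydrogen on the aromatic carbon ortho to two methoxy groups gives a number 25.6 percentage points lower from compound 3 to compound 4 (beyond the scatter), so the lower number is no longer tied to the 2,4,6-trimethoxyphenyl of compound 1 alone. The two trimethoxyphenyl groups cannot be told apart, with a number 4 percentage points higher from compound 1 to compound 4 (within the scatter), which means that 2,3,4-trimethoxyphenyl in place of 2,4,6-trimethoxyphenyl leaves no difference beyond the scatter among these compounds. The 2,3,4-trimethoxyphenyl group also separates clearly from the 2,4-difluorophenyl group, with a number 30.3 percentage points lower from compound 2 to compound 4 (beyond the scatter), whereas the 2,4-dimethoxyphenyl group did not, with a number 4.7 percentage points lower from compound 2 to compound 3 (within the scatter), so among these four compounds the clear division falls between the two-substituent and the three-substituent aryl groups.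

No measurement at hand accounts for why the added methoxy goes with the lower number. Going by these compounds, it remains open whether a hydroxyl, an amine or a longer alkoxy chain on that same aromatic carbon would give a similar number, or whether the step is particular to methoxy.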